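This account rests on a few compounds, and the source may have more. Where it says the series, first, only, none or still open, it means among the compounds named here.

Measured so far in a functional assay on HepG2 cells (Homo sapiens) for cytotoxicity, with a stated time of 72 h; on this read-out higher numbers stand for an effect only at larger amounts of compound and lower numbers for an effect already at smaller amounts:
Compound 1 `C=C[C@@](C)(/C=C/c1ccc(O)c(/C=C/C#N)c1)CCC=C(C)C`: > 52000 nM, a limit
Compound 2 `C=C[C@@](C)(/C=C/c1ccc(O)c(/C=C/C(=O)OCC)c1)CCC=C(C)C`: > 52000 nM, a limit
Not yet measured: compound 3 `C=C[C@@](C)(/C=C/c1ccc(O)c(/C=C/C(=O)OCc2ccccc2)c1)CCC=C(C)C`

Compound 2 stands at > 52000 nM, which is a limit and not a number. Within the data shown here, the only other value, that of compound 1, is a limit as well, so the series so far reads as the limit of > 52000 nM in this assay, at which 2 of the 2 values shown sit.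

The change to compound 3 is phenyl in place of methyl on a saturated chain carbon bound to an oxygen next to a carbonyl group. This turns ethoxycarbonyl into benzyloxycarbonyl.

Among the measured compounds shown here, only one measured step is available, a step that the two limits leave unreadable from compound 1 to compound 2. It concerns a different change, ethoxycarbonyl in place of cyano, and gives no size to carry over. No step beyond the scatter is therefore expected in this assay, in either direction, and a further limit is the likeliest report. For compound 3 the estimated value is 60000 nM. The expected range for compound 3 runs from 25000 nM to 150000 nM. The estimate corresponds to an expected step that the limit leaves unreadable from compound 2 to compound 3.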

Compound 3, half-maximal effective concentration: > 52000 nM
Compound 3 ended at the assay's limit; the forecaster's own chance of this, stated with the estimate: 75%; the middle value lies beyond the limit too.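

In this assay, among these compounds, compound 3 gives > 52000 nM as a limit, so no step between compound 1, compound 2 and compound 3 can be read. The series now reads as a single limit: the limit of > 52000 nM in this assay, at which 3 of the 3 values shown sit.

The compounds shown leave open whether compound 1, compound 2 or compound 3 has any effect at larger amounts, and how they would compare there.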